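The source may report more compounds than this note shows. Statements on the series, on what has been measured and on what is new or still open speak of the compounds shown alone.

Measured compounds:
Compound 1, `OC(CCn1nc2c(Br)c(Br)c(Br)c(Br)c2n1)c1ccc(F)cc1`, gives 88% in a functional assay on CCRF-CEM cells (Homo sapiens) for antiproliferative activity, read by MTT assay, with a stated time of 48 h, tested at 25 uM; on this read-out lower numbers stand for a stronger effect and higher numbers for a weaker effect at the one concentration tested.
Compound 2, `C[C@H](O)CCn1nc2c(Br)c(Br)c(Br)c(Br)c2n1`, gives 89% in this assay.

On these two numbers compound 1 stands close to compound 2; the two read-outs lie within the usual scatter of each other, so no order between them can be drawn and neither can be called the more active. Compound 3, `OC(CCn1nc2c(Br)c(Br)c(Br)c(Br)c2n1)c1ccc(Cl)cc1`, has not yet been measured in this assay. It differs from compound 1 in one place: chloro in place of fluoro on an aromatic carbon. Going by the values given here, no step between measured compounds has been determined here, so there is no measured step of this kind to set a size against. Since compound 1 sits at 88%, the step from compound 1 to compound 3 is expected to be small, a number 3 percentage points lower from compound 1 to compound 3 (within the scatter), not clearly beyond the scatter. Compound 3 is therefore estimated at 85% in this assay, with a range from 72% to 96%.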

Compound 3, a percentage reported as activity, at one concentration (the size of the read-out at that concentration, not a potency): 69%
Compound 3: the middle estimate sits 16 percentage points above what was measured; measured number below the stated range.
By their numbers in this assay, from the lowest: compound 3; then compounds 1 and 2 (each within the scatter of the next).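

Going by these compounds alone, the change from 4-fluorophenyl to 4-chlorophenyl gives the first step between measured compounds in this assay, a number 19 percentage points lower from compound 1 to compound 3 (beyond the scatter), and here the lower number stands for the stronger effect. Within the data shown here, it shows that this place on the aromatic ring is not indifferent to which halogen it carries, a sensitivity that the earlier compounds, with no step between them, could not show. Nothing measured here explains why chloro and fluoro part in this way.

Going by these compounds, whether bromo, methoxy or an amine at the same place would read like compound 3 or like compound 1 remains open. On these data alone, it is also open whether the same exchange would have a comparable effect on a shorter or longer chain between the core and the aromatic ring.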